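The compounds below may be only part of what the source reports. "The series", "measured", "known", "first", "only" and "open" are said of these compounds alone.

Compound 1 `COC(=O)C(Nc1cc(CS(=O)(=O)/C=C/c2c(OC)cc(OC)cc2OC)ccc1OC)c1ccc(Cl)cc1` gives 200 nM in a functional assay on K562 cells (Homo sapiens) for cytotoxicity, read by trypan blue exclusion, with a stated time of 96 h; on this read-out lower numbers stand for stronger inhibition and higher numbers for weaker inhibition. Compound 2 `COC(=O)C(Nc1cc(CS(=O)(=O)/C=C/c2c(OC)cc(OC)cc2OC)ccc1OC)c1ccc(Br)cc1` differs from compound 1 by bromo in place of chloro on an aromatic carbon; in this assay compound 2 gives 200 nM, so that change made no change at the digits printed from compound 1 to compound 2 (within the scatter). Compound 3 `COc1cc(OC)c(/C=C/S(=O)(=O)Cc2ccc(OC)c(NC(C(=O)O)c3ccc(Cl)cc3)c2)c(OC)c1` carries a different core, set apart from compound 1 by hydrogen in place of methyl on an oxygen next to a carbonyl group; in this assay compound 3 gives 250 nM, and the core change reads a 1.3-fold higher number from compound 1 to compound 3 (0.10 log units; within the scatter). Compound 4 `COc1cc(OC)c(/C=C/S(=O)(=O)Cc2ccc(OC)c(NC(C(=O)O)c3ccc(Br)cc3)c2)c(OC)c1` is not yet measured; it stands to compound 3 as compound 2 stands to compound 1, by bromo in place of chloro on an aromatic carbon, and the place of the change is the same in both pairs. Since that change made no change at the digits printed from compound 1 to compound 2 (within the scatter) on the first core, the expected step is no change at the digits printed from compound 3 to compound 4 (within the scatter) in this assay, and compound 4 is estimated at 250 nM, between 150 nM and 450 nM.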

Compound 4, half-maximal inhibitory concentration: 200 nM
Beside the measured number, compound 4's estimate is 1.3-fold (0.10 log units) above it; the range from low to high includes it.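

In this assay, bromo in place of chloro on an aromatic carbon gives a 1.3-fold lower number from compound 3 to compound 4 (0.10 log units; within the scatter), beside no change at the digits printed from compound 1 to compound 2 (within the scatter) on the other core, and the two steps agree: the same change on two cores in this assay, no change at the digits printed (within the scatter) from compound 1 to compound 2 and a 1.3-fold lower number (0.10 log units; within the scatter) from compound 3 to compound 4, 1.3-fold (0.10 log units) apart, within the scatter of two such steps. Hydrogen in place of methyl on the oxygen next to a carbonyl group gives no change at the digits printed from compound 2 to compound 4 (within the scatter), with both changes together giving no change at the digits printed from compound 1 to compound 4 (within the scatter), and this change also agrees across the two cores: the same change on two cores in this assay, a 1.3-fold higher number (0.10 log units; within the scatter) from compound 1 to compound 3 and no change at the digits printed (within the scatter) from compound 2 to compound 4, 1.3-fold (0.10 log units) apart, within the scatter of two such steps. This shows that both changes carry over between these two cores with no step beyond the scatter, but it does not show how a change with a step beyond the scatter would carry over, or how either change would behave on any other core.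

The compounds shown leave open what fluoro or a methyl group would do in place of the chloro or bromo. They also leave open what an amide would do in place of the carboxylic acid or its methyl ester.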